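A few compounds are considered here, and "the series" means these few. Any claim that something is new, unique, unknown or untested is made for them only; others in the source may bear on it.

Compound 1 `CC(C)(C)OC(=O)Nc1cccc(-c2ccc(C(=O)N[C@@H](CCCN=C(N)N)B3O[C@@H]4CC5CC(C5(C)C)[C@]4(C)O3)o2)c1` — 25 nM
Compound 2 `CC(C)(C)OC(=O)Nc1cccc(-c2cccc(C(=O)N[C@@H](CCCN=C(N)N)B3O[C@@H]4CC5CC(C5(C)C)[C@]4(C)O3)c2)c1` — 35 nM

Both compounds were characterised in an assay on isolated protein for inhibition of serine protease 1 (Homo sapiens); on this read-out lower numbers stand for stronger inhibition and higher numbers for weaker inhibition. Compound 2 carries the higher of the two numbers, but its nearest neighbour, compound 1, lies within the usual scatter of it, so the pair shows no difference that can be read as a real change in inhibition. Compound 3 `CC1(C)C2CC1[C@]1(C)OB([C@H](CCCN=C(N)N)NC(=O)c3cccc(-c4ccccc4)c3)O[C@@H]1C2` has not yet been measured in this assay. It differs from compound 2 in a single place: hydrogen in place of (tert-butoxycarbonyl)amino on an aromatic carbon. For the measured compounds named here, no step between measured compounds corresponds to this change, so its effect cannot be taken from the data at hand. The loss of the whole (tert-butoxycarbonyl)amino group is nevertheless expected to cost some inhibition, a moderate weakening rather than one beyond all doubt. The step from compound 2 to compound 3 is expected to be a 2.3-fold higher number from compound 2 to compound 3 (0.36 log units; beyond the scatter). Compound 3 is accordingly estimated at 80 nM, with a range from 25 nM to 300 nM.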

Compound 3, inhibition constant: 7.4 nM
Beside the measured number, compound 3's estimate is 11-fold (1.03 log units) above it; the whole stated range lies above it.
By their numbers in this assay, from the lowest: compound 3; then compounds 1 and 2 (each within the scatter of the next).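

In this assay, hydrogen in place of (tert-butoxycarbonyl)amino on an aromatic carbon gives a 4.7-fold lower number from compound 2 to compound 3 (0.67 log units; beyond the scatter), a modest gain in inhibition that lies beyond the scatter. This shows that the group is not needed at this position on the core of compound 2: all 8 of its heavy atoms can be lost, and inhibition grows stronger rather than weaker. Nothing at hand accounts for this gain.

The compounds shown leave open whether a small group at this position, such as an amine, a methyl group or a carboxylic acid, would match hydrogen or improve on it. They also leave open whether the same change would have a similar effect on the core of compound 1, which carries the same (tert-butoxycarbonyl)amino group.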